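Adding trifluoromethyl to the phenyl of compound 2

This account rests on a few compounds, and the source may have more. Where it says the series, first, only, none or still open, it means among the compounds named here.

In a functional assay on NCI-H1993 cells (Homo sapiens) for inhibition, read by CCK-8 assay, with a stated time of 72 h (a lower number here means a stronger inhibitor, a higher number a weaker inhibitor), compound 1 `Cn1nccc1-c1cnc2ncn(Cc3ccc4ncccc4c3)c2n1` gives 7910 nM and compound 2 `c1ccc(-c2cnc3ncn(Cc4ccc5ncccc5c4)c3n2)cc1` gives 7490 nM. Within the data shown here, these two numbers lie within the scatter of each other, so compound 2 stands level with the only other compound measured. Compound 3 `FC(F)(F)c1ccc(-c2cnc3ncn(Cc4ccc5ncccc5c4)c3n2)cc1` keeps the shared core and turns phenyl into 4-(trifluoromethyl)phenyl, with trifluoromethyl in place of hydrogen on an aromatic carbon, para to a large group (trifluoromethyl in place of hydrogen on an aromatic carbon). Among the measured compounds shown here, only one measured step bears on this, and only loosely: phenyl in place of 1-methyl-1H-pyrazol-5-yl gave a 1.1-fold lower number from compound 1 to compound 2 (0.02 log units; within the scatter). For the measured compounds named here, that step swapped a whole ring, and no measured step adds a group to the phenyl. The data therefore indicate no direction, and no change beyond the scatter is expected in this assay. The expected step is a 1.1-fold lower number from compound 2 to compound 3 (0.03 log units; within the scatter). Compound 3 is estimated at 7000 nM, with an expected range of 2500 nM to 20000 nM.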

Compound 3, half-maximal inhibitory concentration: > 10000 nM
Compound 3 ended at the assay's limit; the forecaster's own chance of this, stated with the estimate: 15%; middle value at least 1.4-fold (0.15 log units) away from the limit.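

Compound 3 gives > 10000 nM in this assay, and this is a limit of the assay and not a number: the limit of > 10000 nM in this assay, at which 1 of the 3 values shown sits.

Adding trifluoromethyl on an aromatic carbon para to a large group gives an at least 1.3-fold higher number from compound 2 to compound 3 (0.12 log units; that floor lies within the scatter) and so offers no sign of a stronger inhibitor, the first such reading for a change on the phenyl itself. Swapping 1-methyl-1H-pyrazol-5-yl for 4-(trifluoromethyl)phenyl gives an at least 1.2-fold higher number from compound 1 to compound 3 (0.10 log units; that floor lies within the scatter) and is likewise only a floor, so the true size of either step cannot be read.

On these data alone, whether any group on this phenyl could bring the number down stays open, since one group at one place shows no trend. A methoxy group, an amine or a carboxylic acid at the same place could behave quite differently.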